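Silyl-ether removal in a diterpenoid lactone series

The source may hold more compounds than are shown below. What is called first, only, known or untested is meant among the compounds shown, and "the series" means these compounds.

Measured compounds in a functional assay on KB cells (Homo sapiens) for cytotoxicity, read by sulforhodamine B assay; on this read-out higher numbers stand for an effect only at larger amounts of compound and lower numbers for an effect already at smaller amounts:
- compound 1, `C=C1CC[C@@H]2[C@](C)(CO[Si](c3ccccc3)(c3ccccc3)C(C)(C)C)[C@H](OC(C)=O)CC[C@@]2(C)[C@@H]1C/C=C1/C(=O)OC[C@H]1OC(C)=O`: 29 uM
- compound 2, `C=C1CC[C@@H]2[C@](C)(CO[Si](C(C)C)(C(C)C)C(C)C)[C@H](OC(C)=O)CC[C@@]2(C)[C@@H]1C/C=C1/C(=O)OC[C@H]1OC(C)=O`: 7.39 uM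
- compound 3, `C=C1CC[C@@H]2[C@](C)(CO[Si](C)(C)C(C)(C)C)[C@H](O)CC[C@@]2(C)[C@@H]1C/C=C1/C(=O)OC[C@H]1O`: 40.7 uM

Compound 2 has the lowest number of the three, and its gaps to compound 1 and to compound 3 both lie beyond the usual scatter, so on these numbers compound 2 is the most potent of the measured set. For the measured compounds named here, compound 1 and compound 3 carry a different silyl group each, and compound 3 also lacks the two acetates; no single-change step between any pair has been established, so only the raw values can be compared.

Compound 4, `C=C1CC[C@@H]2[C@](C)(CO)[C@H](OC(C)=O)CC[C@@]2(C)[C@@H]1C/C=C1/C(=O)OC[C@H]1OC(C)=O`, is not yet measured. Relative to compound 2 the change is a hydrogen atom in place of a group of 10 heavy atoms (9 carbon, 1 silicon; no ring), on an oxygen on a saturated carbon. The group that leaves is the whole silyl protecting group, so compound 4 carries a free hydroxyl on that saturated carbon.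

Expectation: since the two measured compounds that differ only in the nature of the silyl group span a gap beyond the scatter, the silyl portion appears to matter, and its complete removal is expected to move the number upward. The expected step of a 3.0-fold higher number from compound 2 to compound 4 (0.47 log units; beyond the scatter) is a moderate loss, beyond the scatter. Compound 4 is estimated at 22 uM, within 7 uM to 65 uM.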

Compound 4, concentration for half-maximal effect: 11.7 uM
Compound 4: middle estimate off by 1.9-fold (0.27 log units), on the high side; measured number inside the range.
By their numbers in this assay, from the lowest: compounds 2 and 4 (each within the scatter of the next); then compounds 1 and 3 (each within the scatter of the next).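

In this assay, for the compounds shown here, the first one-place comparison, a 1.6-fold higher number from compound 2 to compound 4 (0.20 log units; within the scatter), lies within the scatter, even though the change is large: a hydrogen atom in place of a group of 10 heavy atoms, on an oxygen on a saturated carbon. On these two compounds the silyl group is therefore not required for the value seen in compound 2, and the free hydroxyl of compound 4 gives a number that cannot be told apart from it. No supporting measurement accompanies this step, so the observation stands without an explanation.

Still open, on these data alone, is whether other groups on this oxygen, such as a methyl ether, an acetate or a benzyl ether, would also leave the number unchanged, or whether an amine in place of the hydroxyl would do so. Going by these compounds alone, the role of the two acetates also stays open: compound 3 gives 40.7 uM without them, but it differs from compound 4 in more than one place, so no step on the acetates can be read.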